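This account rests on a few compounds, and the source may have more. Where it says the series, first, only, none or still open, it means among the compounds named here.

Measured so far:
compound 1, `COc1cc(-c2cnn3cc(OC)c(-c4cc(C)no4)nc23)ccn1`, giving 3000 nM in an assay on isolated protein for inhibition of activin receptor type-2A (Homo sapiens), read by 33P incorporation, with a stated time of 20 min, in the presence of a further agent that is not named here; on this read-out lower numbers stand for stronger inhibition and higher numbers for weaker inhibition;
compound 2, `COc1cc(-c2cnn3cc(OC)c([C@@H]4COC(C)(C)C4)nc23)ccn1`, giving 5300 nM in this assay.

On these two numbers compound 2 stands highest, with compound 1 nearest at a step within the scatter, so the two cannot be told apart. Going by the values given here, the only measured step, a 1.8-fold higher number from compound 1 to compound 2 (0.25 log units; within the scatter), came from exchanging one five-membered ring for another on an aromatic carbon of the shared core.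

Compound 3, `COc1cc(-c2cnn3cc(OC)c(N(C)C)nc23)ccn1`, continues at that same carbon: a group of 3 heavy atoms (2 carbon, 1 nitrogen; no ring) in place of a group of 7 heavy atoms (6 carbon, 1 oxygen; one five-membered non-aromatic ring with 1 hetero atom), on an aromatic carbon. This change removes the ring entirely and leaves a small dimethylamino group in its place. Among the compounds with values here, the one measured step bears on it only loosely, since it shows that exchanging the substituent at this carbon, from an aromatic to a non-aromatic ring, moved this assay by no more than the scatter. Within the data shown here, no step from a ring to an open-chain group has been measured, so the weight of evidence is thin.

Compound 3 is therefore expected to give about 4500 nM in this assay, with a range from 1500 nM to 14000 nM. The step this implies, a 1.2-fold lower number from compound 2 to compound 3 (0.07 log units; within the scatter), is expected to be small, in no certain direction.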

Compound 3, half-maximal inhibitory concentration: 3000 nM
Compound 3: middle estimate off by 1.5-fold (0.18 log units), on the high side; the measured number falls inside the stated range.
By their numbers in this assay, from the lowest: compounds 1, 3 and 2 (each within the scatter of the next).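

In this assay, putting dimethylamino on this aromatic carbon in place of the oxygen-containing ring gives a 1.8-fold lower number from compound 2 to compound 3 (0.25 log units; within the scatter), and putting it in place of 3-methyl-1,2-oxazol-5-yl gives no change at the digits printed from compound 1 to compound 3 (within the scatter). Going by these compounds alone, the earlier pair compared only two ring-bearing groups, whereas these steps add a small group with no ring, and all three compounds still lie within the scatter of one another. Among these three compounds, then, neither a ring at this carbon, aromatic or not, nor the larger size of the ring-bearing groups separates the numbers, and nothing available here offers an explanation for this flat result.

What stays open is whether any group on this carbon can move the number in this assay beyond the scatter, as all three groups shown leave it indistinguishable. A primary amine, a morpholine ring, a carboxylic acid or a longer alkyl chain at this carbon would test that, and the compounds shown also leave unanswered how the number responds to changes elsewhere on the shared core, such as at either methoxy group.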